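Swapping One Aromatic Group in a Cytotoxicity Series

The source may hold more compounds than are shown below. What is called first, only, known or untested is meant among the compounds shown, and "the series" means these compounds.

Measured in an ADME assay on HEK293 cells (Homo sapiens) for cytotoxicity, read by MTT assay, with a stated time of 72 h; on this read-out higher numbers stand for weaker inhibition and lower numbers for stronger inhibition:
compound 1 `O=C(CN1CCN(C(=O)c2ccc(Cl)cc2)CC1)N1CCN(CCCc2c[nH]c3ccccc23)CC1`: 98200 nM
compound 2 `COc1cccc(C(=O)N2CCN(CC(=O)N3CCN(CCCc4c[nH]c5ccccc45)CC3)CC2)c1`: 143000 nM
compound 3 `O=C(CN1CCN(C(=O)c2ccc(Cl)cc2)CC1)N1CCN(CCCc2c[nH]c3ccc(F)cc23)CC1`: 44500 nM

Among these three, compound 3 has the lowest number, 44500 nM. Compound 4 `O=C(CN1CCN(C(=O)c2cccc(F)c2)CC1)N1CCN(CCCc2c[nH]c3ccc(F)cc23)CC1` has not been measured yet. Its difference from compound 3 is 3-fluorophenyl in place of 4-chlorophenyl on a carbonyl carbon. Put simply, it has 3-fluorophenyl in place of 4-chlorophenyl on a carbonyl carbon.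

Within the data shown here, two measured steps bear on this. The closer parallel is a 1.5-fold higher number from compound 1 to compound 2 (0.16 log units; within the scatter), which also replaces 4-chlorophenyl on a carbonyl carbon, in that case with 3-methoxyphenyl. That step is small and gives no sign that such a swap moves the number in this assay. The other is a 2.2-fold lower number from compound 1 to compound 3 (0.34 log units; beyond the scatter), a modest step from adding fluoro in place of hydrogen on an aromatic carbon. Compound 4 keeps that fluoro, so this step says little about the new swap. Among the measured compounds shown here, no measured pair shows the 3-fluorophenyl group itself, so the forecast rests on a single parallel. The expected change is small, at a 1.2-fold higher number from compound 3 to compound 4 (0.09 log units; within the scatter), with no clear shift beyond the scatter, though a slight rise is allowed for. For compound 4 the estimated value is 55000 nM, with an expected range from 25000 nM to 120000 nM.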

Compound 4, half-maximal inhibitory concentration: 83000 nM
For compound 4 the middle estimate is 1.5-fold (0.18 log units) below the measured one; the measured number falls inside the stated range.
By their numbers in this assay, from the lowest: compounds 3, 4, 1 and 2 (each within the scatter of the next, the first and the last beyond it).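

In this assay the change to 3-fluorophenyl gives a 1.9-fold higher number from compound 3 to compound 4 (0.27 log units; within the scatter) and so shows no clear shift at this position on the carbonyl carbon, now on the fluorinated core of compound 3 as well. Set beside a 1.5-fold higher number from compound 1 to compound 2 (0.16 log units; within the scatter) from the earlier series, this makes two replacements of 4-chlorophenyl, with different incoming aromatic groups and on cores that differ by one fluoro, and neither goes beyond the usual scatter, although two steps are a thin basis for a pattern and none of the compounds shown goes against it. Nothing at hand explains why this position tolerates both swaps in this cell-based read-out.

As far as these compounds go, it remains open whether a group of a different kind on the same carbonyl carbon, such as a cyclohexyl ring, an amine or a carboxylic acid, would produce a step beyond the scatter. From the compounds shown here alone, it also remains open how 3-fluorophenyl would behave on the core of compound 1, which lacks the fluoro, and whether 4-fluorophenyl would read any differently from the 3-fluorophenyl group in compound 4.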